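This account rests on a few compounds, and the source may have more. Where it says the series, first, only, none or still open, it means among the compounds named here.

The measured compounds in an ADME assay (liver) for pharmacokinetics, with Liver microsome (Rattus norvegicus) as the target, using microsomes (a higher number here means that the compound lasts longer, a lower number that the compound disappears faster), are:
compound 1 `CCOc1cc(NC(=O)C2(NC(=O)c3ccc4c(C5CCCC5)c(-c5ncc(Cl)cn5)n(C)c4c3)CCC2)ccc1/C=C/C(=O)OC(=O)C[C@H](O)C(=O)O`, giving 7.92 h;
compound 2 `CCOc1cc(NC(=O)C2(NC(=O)c3ccc4c(C5CCCC5)c(-c5ncc(Cl)cn5)n(C)c4c3)CCC2)ccc1/C=C/C(=O)OCc1ccccc1`, giving 2.17 h;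
compound 3 `CCOc1cc(NC(=O)C2(NC(=O)c3ccc4c(C5CCCC5)c(-c5ncc(Cl)cn5)n(C)c4c3)CCC2)ccc1/C=C/C(=O)OCCOc1ccccc1`, giving 16.5 h.

Compound 1 stands second of the three: the step of a 2.1-fold higher number from compound 1 to compound 3 (0.32 log units; beyond the scatter) runs upward beyond the scatter, and the step of a 3.6-fold lower number from compound 1 to compound 2 (0.56 log units; beyond the scatter) runs downward beyond the scatter.

Compound 4 `CCOc1cc(NC(=O)C2(NC(=O)c3ccc4c(C5CCCC5)c(-c5ncc(Cl)cn5)n(C)c4c3)CCC2)ccc1/C=C/C(=O)OCCOCCOC` differs from compound 1 in one place: 2-(2-methoxyethoxy)ethyl in place of (2-carboxy-2-hydroxyethyl)carbonyl on an oxygen next to a carbonyl group. Both measured steps bear on this change, since each also replaces the (2-carboxy-2-hydroxyethyl)carbonyl group on that oxygen. The step of a 2.1-fold higher number from compound 1 to compound 3 (0.32 log units; beyond the scatter), which brings in the 2-phenoxyethyl chain, is the nearer comparison, and the step of a 7.6-fold higher number from compound 2 to compound 3 (0.88 log units; beyond the scatter) points the same way. Compound 4 is therefore expected to show a modest upward step of a 1.4-fold higher number from compound 1 to compound 4 (0.14 log units; within the scatter) in this assay. The estimated half-life of compound 4 is 11 h, within a range of 4.5 h to 27 h.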

Compound 4, half-life: 1.07 h
Beside the measured number, compound 4's estimate is 10-fold (1.01 log units) above it; measured number below the stated range.
By their numbers in this assay, from the lowest: compound 4; then compound 2; then compound 1; then compound 3.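

Replacing the (2-carboxy-2-hydroxyethyl)carbonyl group on this oxygen next to a carbonyl group does not always raise the number in this assay here: 2-(2-methoxyethoxy)ethyl gives a drop (a 7.4-fold lower number from compound 1 to compound 4 (0.87 log units; beyond the scatter)), whereas the 2-phenoxyethyl chain gave a rise. Chains ending in phenyl and phenoxy do not match it either, with 2-methoxyethyl in place of phenyl (a 15-fold lower number from compound 3 to compound 4 (1.19 log units; beyond the scatter)) and (2-methoxyethoxy)methyl in place of phenyl (a 2.0-fold lower number from compound 2 to compound 4 (0.31 log units; beyond the scatter)) both lowering the number. Nothing available explains this drop.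

The compounds shown leave open whether the ring or the chain length governs the number. On these data alone, how a 2-aminoethyl chain on this oxygen would compare also stays open.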